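From an inactive compound to a thiophene

This account rests on a few compounds, and the source may have more. Where it says the series, first, only, none or still open, it means among the compounds named here.

In a functional assay on A549 cells (Homo sapiens) for inhibition, read by sulforhodamine B assay, with a stated time of 74 h (on this read-out higher numbers stand for weaker inhibition and lower numbers for stronger inhibition), compound 1 `Cc1ccc(S(=O)(=O)N2C(=O)COC23C=CC(=O)C=C3)cc1` gives 110 nM. Compound 2 `Cc1ccccc1S(=O)(=O)N1C(=O)COC12C=CC(=O)C=C2` reads > 10000 nM, which is a limit of the assay and not a number. Compound 3 `O=C1C=CC2(C=C1)OCC(=O)N2S(=O)(=O)c1cccs1` differs from it by thiophen-2-yl in place of 2-methylphenyl on a sulfonyl sulfur. Going by the values given here, the only measured step that bears on this is an at least 90-fold higher number from compound 1 to compound 2 (1.95 log units; beyond the scatter), a large change made by 2-methylphenyl in place of 4-methylphenyl. With 2-methylphenyl gone, much of that loss may return, so stronger inhibition is expected, though not fully reaching that of compound 1, which gives 110 nM. The expected change is an at least 16-fold lower number from compound 2 to compound 3 (1.22 log units; beyond the scatter). For compound 3 the estimate is 600 nM, with an expected range of 90 nM to 6000 nM.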

Compound 3, half-maximal inhibitory concentration: > 10000 nM
Compound 3: a limit, no number; the forecaster's own chance of this, stated with the estimate: 15%; at least 16-fold (1.22 log units) between middle value and limit.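

Thiophen-2-yl in place of 4-methylphenyl on the sulfonyl sulfur also loses the inhibition of compound 1: in this assay there is an at least 90-fold higher number from compound 1 to compound 3 (1.95 log units; beyond the scatter). So 2-methylphenyl is no longer the only group at this place that reads this way. The step from compound 2 to compound 3 cannot be read, as both values are limits and not numbers: the limit of > 10000 nM in this assay, at which 2 of the 3 values shown sit.

Open, going by these compounds, is how a plain phenyl or a 4-methoxyphenyl group on the sulfonyl sulfur would read. Such groups could show whether 4-methylphenyl is special here.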